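A few compounds are considered here, and "the series" means these few. Any claim that something is new, unique, unknown or untested is made for them only; others in the source may bear on it.

In a functional assay for inhibition, with Homo sapiens as the target (on this read-out higher numbers stand for weaker inhibition and lower numbers for stronger inhibition), compound 1 (`COc1cc(OC)c(C(=O)/C=C/c2c(Cl)cccc2Cl)c(OC)c1`) gives 1090 nM. Compound 2 (`COc1cc(OC)c(C(=O)/C=C/c2cccc3ccccc23)c(OC)c1`) gives 1350 nM and compound 3 (`COc1cc(OC)c(C(=O)/C=C/c2ccc3ccccc3c2)c(OC)c1`) gives 2150 nM. Compound 1 therefore lies within the scatter of both, and the three numbers do not separate. Compound 4 (`COc1cc(OC)c(C(=O)/C=C/c2cnccn2)c(OC)c1`) has not yet been measured in this assay. It carries pyrazin-2-yl in place of 2,6-dichlorophenyl on a double-bonded chain carbon bound to a double-bonded chain carbon. Among the compounds with values here, no measured compound has a ring with hetero atoms at that place, so the data offer no direct guide. A step beyond the scatter towards weaker inhibition is expected, estimated as a 4.6-fold higher number from compound 1 to compound 4 (0.66 log units; beyond the scatter). For compound 4 the expected value is 5000 nM, with an estimated range of 1800 nM to 15000 nM.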

Compound 4, half-maximal inhibitory concentration: 693 nM
For compound 4 the middle estimate is 7.2-fold (0.86 log units) above the measured one; the whole stated range lies above it.
By their numbers in this assay, from the lowest: compounds 4, 1, 2 and 3 (each within the scatter of the next, the first and the last beyond it).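

At this place, on a double-bonded chain carbon bound to a double-bonded chain carbon, a ring with hetero atoms is accepted: in this assay, pyrazin-2-yl in place of 2,6-dichlorophenyl gives a 1.6-fold lower number from compound 1 to compound 4 (0.20 log units; within the scatter) and so no separation. The ring with hetero atoms, its two hydrogen-bond acceptors and the loss of both chlorines therefore leave the read-out within the scatter. Nothing at hand explains this outcome.

Still open, on these data alone, is how pyridin-2-yl, or a phenyl ring carrying a carboxylic acid or an amine, would read at this place.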